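This account rests on a few compounds, and the source may have more. Where it says the series, first, only, none or still open, it means among the compounds named here.

Working notes on the series. Compound 1 `Oc1cccc(-c2cc(-c3ccc(C(F)(F)F)cc3)cc(-c3ccccc3O)n2)c1` and compound 2 `Oc1ccc(-c2cc(-c3ccc(C(F)(F)F)cc3)cc(-c3ccccc3O)n2)cc1` share one core and differ at a single point: 4-hydroxyphenyl in place of 3-hydroxyphenyl on an aromatic carbon. In a functional assay on DU-145 cells (Homo sapiens) for inhibition (on this read-out higher numbers stand for weaker inhibition and lower numbers for stronger inhibition), compound 1 reports > 50000 nM, which is a limit of the assay and not a number. In this assay compound 2 reports > 50000 nM, again a limit. The step between them is therefore a step that the two limits leave unreadable from compound 1 to compound 2, unreadable because of the limit of > 50000 nM in this assay, at which 2 of the 3 values shown sit.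

Compound 3 `Oc1ccc(-c2cc(-c3ccccc3C(F)(F)F)cc(-c3cccc(O)c3)n2)cc1` rests on a different core; the difference between the two cores is not broken down here. In this assay, going by the values given here, compound 3 gives 2750 nM, the only plain number in the set.

Compound 4 `Oc1ccc(-c2cc(-c3ccccc3C(F)(F)F)cc(-c3ccc(O)cc3)n2)cc1` is not yet measured. It stands to compound 3 as compound 2 stands to compound 1: 4-hydroxyphenyl in place of 3-hydroxyphenyl on an aromatic carbon. This is the same kind of change, not the same change. In compound 1 the place is meta to a 2-hydroxyphenyl group and meta to a 4-(trifluoromethyl)phenyl group, whereas in compound 3 the place is meta to a 2-(trifluoromethyl)phenyl group and meta to a 4-hydroxyphenyl group.

Among the compounds with values here, the one measured instance of this change carries no readable size. The expected step is a 1.5-fold higher number from compound 3 to compound 4 (0.16 log units; within the scatter), set near zero and resting on compound 3 at 2750 nM alone, with wide uncertainty in both directions. Compound 4 is accordingly estimated at 4000 nM, within a range from 1000 nM to 20000 nM.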

Compound 4, half-maximal inhibitory concentration: > 50000 nM
Compound 4 gave a limit, no number; the forecaster's own chance of this, stated with the estimate: 20%; middle value at least 12-fold (1.09 log units) from the limit.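

On the core of compound 3, 4-hydroxyphenyl in place of 3-hydroxyphenyl has a large effect in this assay: the change gives an at least 18-fold higher number from compound 3 to compound 4 (1.25 log units; beyond the scatter), which is beyond the scatter. That size is only a lower bound: compound 4 reports > 50000 nM, a limit of the assay and not a number. The same change on the core of compound 1 cannot be read, so the series offers one sized instance and no test of whether that size carries from one core to the other, and the readable range of the set is narrow: the limit of > 50000 nM in this assay, at which 3 of the 4 values shown sit.

The compounds shown leave open which feature of compound 3 goes with its measurable value, since no pair here separates the 2-(trifluoromethyl)phenyl group from the rest of that core. Also open, on these data alone, is how this place on the core would respond to a group other than a hydroxyphenyl, such as an aminophenyl group or a phenyl group carrying a carboxylic acid.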